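Shortening the Amide Chain Further: Compound 3 Expected Weaker

This account rests on a few compounds, and the source may have more. Where it says the series, first, only, none or still open, it means among the compounds named here.

Two compounds were measured in a functional assay on SK-OV-3 cells (Homo sapiens) for cytotoxicity, read by MTT assay; on this read-out higher numbers stand for weaker inhibition and lower numbers for stronger inhibition:
Compound 1 `CCCCCCCCCCCCCC(=O)Nc1cc2c(cc1F)c(=O)c(C(=O)OCC)cn2CC` gives 8200 nM.
Compound 2 `C=CCCCCCCCCC(=O)Nc1cc2c(cc1F)c(=O)c(C(=O)OCC)cn2CC` gives 91200 nM.

Among the compounds with values here, compound 2 stands highest of the two numbers; its only neighbour is compound 1, and the measured step between them was an 11-fold higher number from compound 1 to compound 2 (1.05 log units; beyond the scatter), a large weakening that came with vinyl in place of pentyl on a saturated chain carbon, eight bonds along the chain from a carbonyl carbon. Compound 3 `CCCCCCCC(=O)Nc1cc2c(cc1F)c(=O)c(C(=O)OCC)cn2CC` keeps the shared core and carries a still shorter amide chain. Its change from compound 2 is hydrogen in place of allyl on a saturated chain carbon, seven bonds along the chain from a carbonyl carbon; cut one bond further out, the same difference reads pent-4-en-1-yl to ethyl. Within the data shown here, only one measured step bears on this, the one from compound 1 to compound 2, and it points toward weaker inhibition as the chain is cut back. A step in the same direction is therefore expected here, though with a single precedent its size is uncertain. The expected step is a 2.2-fold higher number from compound 2 to compound 3 (0.34 log units; beyond the scatter). Compound 3 is estimated at 200000 nM, within 50000 nM to 600000 nM, with a real chance that only a limit is reported.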

Compound 3, half-maximal inhibitory concentration in the SK-OV-3 assay: 8100 nM
Compound 3: the middle estimate sits 25-fold (1.39 log units) above what was measured; measured number outside the range, below it.
By their numbers in the SK-OV-3 assay, from the lowest: compounds 3 and 1 (each within the scatter of the next); then compound 2.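

In the SK-OV-3 assay the weakening did not continue as the chain was cut back: hydrogen in place of allyl gave a large step the other way (an 11-fold lower number from compound 2 to compound 3 (1.05 log units; beyond the scatter)), while hydrogen in place of hexyl left the number where it was (a 1.0-fold lower number from compound 1 to compound 3 (0.01 log units; within the scatter)). So, among these three compounds, the number does not simply track chain length: the saturated chains of compound 1 and compound 3 read alike, and compound 2, with its terminal double bond, is the one that stands apart. In a physicochemical assay (on this read-out higher numbers stand for an effect only at larger amounts of compound and lower numbers for an effect already at smaller amounts), compound 2 gives 148 ug/mL and compound 3 gives 110 ug/mL as its value, and these two read alike (a 1.3-fold lower number from compound 2 to compound 3 (0.13 log units; within the scatter)), while no evidence at hand explains the large step in cell cytotoxicity.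

The three compounds leave open whether the double bond or the particular chain length goes with the high number of compound 2, a question that a saturated chain of matching length would address. From the compounds shown here alone, how an amine or a carboxylic acid in place of the allyl group would read also stays open.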